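This account rests on a few compounds, and the source may have more. Where it says the series, first, only, none or still open, it means among the compounds named here.

Three compounds sharing one core were examined in an in vitro functional assay on HEK293-A cells for antagonist activity at metabotropic glutamate receptor 5 (Rattus norvegicus), read by calcium flux; a lower number here means a stronger inhibitor, a higher number a weaker inhibitor. Compound 1 `COc1ccccc1C(=O)Nc1cccc(NC(=O)c2ccc(Cl)cc2)c1` gives > 30000 nM, which is a limit of the assay rather than a number. Compound 2 `COc1ccccc1C(=O)Nc1cccc(NC(=O)C2CC2)c1` gives > 30000 nM, also a limit. Compound 3 `O=C(Nc1cccc(NC(=O)c2cccc(Cl)c2)c1)c1ccc(Cl)cc1` gives > 30000 nM, again a limit and not a number. The step that the two limits leave unreadable from compound 1 to compound 2 and the step that the two limits leave unreadable from compound 1 to compound 3 cannot be sized because of the limit of > 30000 nM in this assay, at which 3 of the 3 values shown sit. Compound 4 `O=C(Nc1cccc(NC(=O)c2cccc(Cl)c2)c1)c1cccc(F)c1` differs from compound 3 by 3-fluorophenyl in place of 4-chlorophenyl on a carbonyl carbon. Within the data shown here, no measured step of readable size bears on this change, so neither direction nor size can be drawn from the measured compounds. Compound 4 is expected to give 30000 nM in this assay, in a range from 10000 nM to 100000 nM, most probably once more as a limit. The estimated step of a number no higher from compound 3 to compound 4 (the limit leaves the size open) is expected to be none beyond the scatter.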

Compound 4, half-maximal inhibitory concentration: > 30000 nM
Compound 4: no number, only a limit (the forecaster's own chance of this, stated with the estimate: 85%); the middle value lies on the limit itself.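

The step from compound 3 to compound 4 cannot be read, as both compounds give a limit and not a number: the limit of > 30000 nM in this assay, at which 4 of the 4 values shown sit. The compounds shown leave open which change to the shared core, if any, would give a readable value in this assay.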